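A few compounds are considered here, and "the series" means these few. Any claim that something is new, unique, unknown or untested is made for them only; others in the source may bear on it.

Working notes on the series.

Compound 1, `CC1CC=C(C(=O)N(c2cc(C#CC(C)(C)C)sc2C(=O)O)C(C)C)CC1`, is the reference point. In an ADME assay on MT4 cells (Homo sapiens) for cytotoxicity, with a stated time of 5 days (a higher number here means that more compound is tolerated, a lower number that less compound is tolerated), compound 1 returns only a limit, > 20000 nM, not a number. The same holds for the two companions. Compound 2, `CC(C)(C)C#Cc1cc(N(C(=O)[C@H]2CC[C@H](C)CC2)[C@H]2CC[C@@](O)(CO[C@H]3CCOC3)CC2)c(C(=O)O)s1`, sits at the limit in this assay with > 20000 nM. Compound 3, `CC(C)(C)C#Cc1cc(N(C(=O)[C@H]2CC[C@H](C)CC2)[C@H]2CC[C@H](Oc3ccncn3)CC2)c(C(=O)O)s1`, likewise gives a limit in this assay, > 20000 nM. Compound 1 therefore stands nowhere in particular on the numbers shown: every value in this assay is a limit, and no ranking among compound 1, compound 2 and compound 3 is possible. What the measurements do show is the limit of > 20000 nM in this assay, at which 3 of the 3 values shown sit.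

The unmeasured compound 4, `CC(C)N(C(=O)C1CCC(F)(F)CC1)c1cc(C#CC(C)(C)C)sc1C(=O)O`, differs from compound 1 in a single place: 4,4-difluorocyclohexyl in place of 4-methylcyclohex-1-en-1-yl on a carbonyl carbon. The change puts 4,4-difluorocyclohexyl where 4-methylcyclohex-1-en-1-yl stood, on the carbonyl carbon bound to the amide-type nitrogen. No measured step in the series carries the same change, so the expected size of the step rests only on the limits shown. The expectation for this assay is a step of no size beyond the scatter, most likely again a limit, which is what a step that the limit leaves unreadable from compound 1 to compound 4 is meant to express. Compound 4 is accordingly estimated at 25000 nM, with a plausible range from 8000 nM to 80000 nM, and the assay is expected to report a limit rather than a number.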

Compound 4, half-maximal cytotoxic concentration: > 20000 nM
Compound 4: no number, only a limit; the forecaster's own chance of this, stated with the estimate: 85%; the middle value does not contradict the limit.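

In this assay compound 4 gives > 20000 nM, a limit and not a number. Among these compounds, compound 1 also returns only a limit, so no step between compound 1 and compound 4 can be read. The compounds shown leave open whether they differ at all in tolerated concentration, and how they would rank: the limit of > 20000 nM in this assay, at which 4 of the 4 values shown sit.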